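The compounds below may be only part of what the source reports. "The series", "measured", "known", "first", "only" and "open" are said of these compounds alone.

The study follows a small set of compounds built on a shared core and tested in an assay on isolated protein with Bile acid receptor (Homo sapiens) as the target; a lower number here means that less compound is needed, a higher number that more compound is needed for the effect. Compound 1 `COC(=O)/C=C/c1cccc(N(Cc2ccc(/C=C/c3c(F)cccc3F)cc2)C(=O)C(C)C)c1` gives 108 nM in this assay. Compound 2 `COC(=O)/C=C/c1cccc(N(Cc2ccc(-c3ccc(C)cc3)cc2)C(=O)NC(C)C)c1` gives 449 nM in this assay. Of the two measured numbers, compound 1 has the lower one, and its gap to compound 2 lies beyond the usual scatter; the two compounds differ in more than one place, so their values alone do not isolate any single change.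

Compound 3 `COC(=O)/C=C/c1cccc(N(Cc2ccc(-c3cccc(OC(F)(F)F)c3)cc2)C(=O)C(C)C)c1` has not yet been measured in this assay. It is compound 1 with one change: 3-(trifluoromethoxy)phenyl in place of 2-(2,6-difluorophenyl)ethenyl on an aromatic carbon. Among the compounds with values here, no measured pair shows this change on its own, so the direction rests on the two values at hand. Because compound 1 sits at 108 nM while compound 2 sits at 449 nM, a step of moderate size towards a higher number is expected, though it could stay within the scatter. The step from compound 1 to compound 3 is estimated at a 2.3-fold higher number from compound 1 to compound 3 (0.36 log units; beyond the scatter). For compound 3 the expected value in this assay is 250 nM, with a range from 80 nM to 800 nM.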

Compound 3, half-maximal effective concentration: 247 nM
Estimate against measurement, compound 3: 1.0-fold (0.01 log units) above, within the range that was stated.
By their numbers in this assay, from the lowest: compound 1; then compounds 3 and 2 (each within the scatter of the next).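

Within the data shown here, on the aromatic carbon para to a large group, putting 3-(trifluoromethoxy)phenyl in place of 2-(2,6-difluorophenyl)ethenyl gives a 2.3-fold higher number from compound 1 to compound 3 (0.36 log units; beyond the scatter) in this assay, and this is the only step in the set that isolates a single change. The exchange drops the double bond outside aromatic rings and brings in a hydrogen-bond acceptor, yet the step is modest, so this position accepts two quite different groups, each carrying a six-membered aromatic ring of carbon only, without a large loss in this assay. Nothing at hand explains the step or divides it among the lost double bond, the fluorine pattern and the new oxygen.

Still open, on these data alone, is whether the ethenyl link or the substituents on the outer ring account for the step, and how a 2,6-difluorophenyl group in the same place would compare with compound 1 and compound 3. Equally open, as far as these compounds go, is how an outer ring bearing an amine or a carboxylic acid would read in this assay.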